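The compounds below may be only part of what the source reports. "The series", "measured", "known", "first", "only" and "open" are said of these compounds alone.

In a functional assay on DU-145 cells (Homo sapiens) for cytotoxicity, read by sulforhodamine B assay, with a stated time of 48 h (a higher number here means a weaker inhibitor, a lower number a stronger inhibitor), three compounds have been measured so far. Compound 1 `CC(=O)OC[C@H]1O[C@@H](n2cc(CN3C(=O)/C(=C\c4ccccc4)c4ccccc43)nn2)[C@H](OC(C)=O)[C@@H](OC(C)=O)[C@@H]1OC(C)=O` gives 24100 nM, compound 2 `CC(=O)OC[C@H]1O[C@@H](n2cc(CN3C(=O)/C(=C/c4ccccc4)c4ccccc43)nn2)[C@H](OC(C)=O)[C@@H](OC(C)=O)[C@@H]1OC(C)=O` gives 22800 nM, and compound 3 `CC(=O)OC[C@H]1O[C@@H](n2cc(CN3C(=O)/C(=C/c4ccc(C)cc4)c4ccccc43)nn2)[C@H](OC(C)=O)[C@@H](OC(C)=O)[C@@H]1OC(C)=O` gives 9300 nM. Compound 3 thus holds the lowest number of the three: the step reaching it was a 2.5-fold lower number from compound 2 to compound 3 (0.39 log units; beyond the scatter), and compound 1 sits a similar distance away from it.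

Compound 4 `CC(=O)OC[C@H]1O[C@@H](n2cc(CN3C(=O)/C(=C\c4ccc(C)cc4)c4ccccc43)nn2)[C@H](OC(C)=O)[C@@H](OC(C)=O)[C@@H]1OC(C)=O` has not yet been measured. Its relation to compound 3 is the two compounds have the same atoms and bonds and differ only in configuration as drawn: 1 of 6 stereo elements differ; a double bond is drawn E in compound 3 and Z in compound 4. Among the compounds with values here, one measured step bears directly on this kind of change: a 1.1-fold lower number from compound 1 to compound 2 (0.02 log units; within the scatter). Since (the fact that compounds 1 and 2 differ only in the configuration as drawn), that step compares exactly the two drawn forms of the same double bond, and it shows them giving numbers that cannot be told apart in this assay. The change from compound 3 to compound 4 turns the same element of drawing the other way round, so no step beyond the usual scatter is expected in this assay, in either direction.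

Compound 4 is therefore expected to give about 10000 nM, with a likely range from 5000 nM to 20000 nM. This expectation amounts to a step of a 1.1-fold higher number from compound 3 to compound 4 (0.03 log units; within the scatter).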

Compound 4, half-maximal inhibitory concentration: 9400 nM
Beside the measured number, compound 4's estimate is 1.1-fold (0.03 log units) above it; the range from low to high includes it.
By their numbers in this assay, from the lowest: compounds 3 and 4 (each within the scatter of the next); then compounds 2 and 1 (each within the scatter of the next).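

The step of a 1.0-fold higher number from compound 3 to compound 4 (0.00 log units; within the scatter) is a pure change of drawn configuration, and like the earlier one it stays within the scatter, so the two drawn forms of this double bond cannot be told apart in this assay on the methyl-bearing compounds either: the fact that compounds 3 and 4 differ only in the configuration as drawn. The methyl change can now also be read a second time, on the other drawn form of the double bond, as a modest step of a 2.6-fold lower number from compound 1 to compound 4 (0.41 log units; beyond the scatter). Methyl in place of hydrogen on an aromatic carbon therefore gives a step of about the same size on both forms, and the two changes show no sign of depending on each other in these four compounds: the same change on two cores in this assay, a 2.5-fold lower number (0.39 log units; beyond the scatter) from compound 2 to compound 3 and a 2.6-fold lower number (0.41 log units; beyond the scatter) from compound 1 to compound 4, 1.0-fold (0.02 log units) apart, within the scatter of two such steps.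

Going by these compounds, only hydrogen and methyl appear at this aromatic carbon, so it remains open whether a larger alkyl chain, a methoxy group, a chlorine atom or a carboxylic acid there would lower the number further, leave it alone or raise it. The acetyl groups stay the same throughout, which leaves open how the same compounds would read with free hydroxyl groups in their place.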